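Dropping a Chlorine from the Benzamide Aryl Ring

The source may report more compounds than this note shows. Statements on the series, on what has been measured and on what is new or still open speak of the compounds shown alone.

Two measured compounds share a core carrying a pyridine and a chlorophenyl group. Compound 1 `O=C(Nc1cccc(-n2cc(-c3ccncc3)c(-c3ccc(Cl)c(O)c3)n2)c1)Nc1ccc(Cl)c(Cl)c1` is a urea, and in a functional assay on NCI-H23 cells (Homo sapiens) for inhibition, read by sulforhodamine B assay, with a stated time of 48 h (on this read-out higher numbers stand for weaker inhibition of growth and lower numbers for stronger inhibition of growth), compound 1 gives 1220 nM. Compound 2 `COc1cc(-c2nn(-c3cccc(NC(=O)c4ccc(Cl)c(C(F)(F)F)c4)c3)cc2-c2ccncc2)ccc1Cl` is an amide, and in this assay compound 2 gives 5390 nM, the higher of the two numbers, so it is the weaker grower-inhibitor of the pair. For the measured compounds named here, no pair among the measured compounds differs in one place, so no measured step exists.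

Compound 3 `COc1cc(-c2nn(-c3cccc(NC(=O)c4cccc(C(F)(F)F)c4)c3)cc2-c2ccncc2)ccc1Cl` is the unmeasured neighbour of compound 2, differing only in that (hydrogen in place of chloro on an aromatic carbon). Nothing measured here shows what this single change does, so the expectation rests on compound 2 alone. The step from compound 2 to compound 3 is expected to be a 1.3-fold higher number from compound 2 to compound 3 (0.11 log units; within the scatter), small and within or near the scatter. Compound 3 is therefore estimated at 7000 nM, with a likely range from 2500 nM to 20000 nM.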

Compound 3, concentration for 50% growth inhibition: 1560 nM
For compound 3 the middle estimate is 4.5-fold (0.65 log units) above the measured one, and the stated range ends above it.
By their numbers in this assay, from the lowest: compounds 1 and 3 (each within the scatter of the next); then compound 2.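

In this assay, going from the 4-chloro-3-(trifluoromethyl)phenyl group to the 3-(trifluoromethyl)phenyl group gives a 3.5-fold lower number from compound 2 to compound 3 (0.54 log units; beyond the scatter) and so a stronger inhibition of growth. For the compounds shown here, this is the first direct reading of this position, since compound 1 and compound 2 differ in more than one place and their gap could not isolate the chloro group. In this pair, the chloro group ortho to the trifluoromethyl group is not needed for growth inhibition, and hydrogen at that carbon does better than chloro.

Still open, as far as these compounds go, is how a fluoro, methyl or amino group at this same carbon would compare, and whether removing a chlorine from the dichlorophenyl ring of the urea compound 1 would have a similar effect. No measurement here offers an explanation for the step.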